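Two Ester Swaps, One Pyrrole Core, Second Pair Untested

A few compounds are considered here, and "the series" means these few. Any claim that something is new, unique, unknown or untested is made for them only; others in the source may bear on it.

Four esters built on one shared core were examined in an assay on HL-60 cells for agonist activity at vitamin D3 receptor (Homo sapiens), read by microscopy, with a stated time of 96 h; on this read-out lower numbers stand for an effect already at smaller amounts and higher numbers for an effect only at larger amounts of compound. Compound 1 `CCn1c(C(=O)OCc2ccccn2)ccc1C(CC)(CC)c1ccc(OCC(=O)C(C)(C)C)c(C)c1` gives in this assay a value that is only a limit, > 50000 nM. Compound 2 `CCn1c(C(=O)OCc2ccc(F)cc2)ccc1C(CC)(CC)c1ccc(OCC(=O)C(C)(C)C)c(C)c1` gives 9500 nM in this assay. The change between them, (4-fluorophenyl in place of pyridin-2-yl on a saturated chain carbon bound to an oxygen next to a carbonyl group), brought an at least 5.2-fold lower number from compound 1 to compound 2 (0.72 log units; beyond the scatter). Compound 3 `CCn1c(C(=O)OCc2ccccn2)ccc1C(CC)(CC)c1ccc(OCC(O)C(C)(C)C)c(C)c1` differs from compound 1 in its core by 1-hydroxy-2,2-dimethylpropyl in place of (tert-butyl)carbonyl on a saturated chain carbon bound to an oxygen on an aromatic ring. In this assay compound 3 likewise gives only a limit, > 50000 nM. The step that the two limits leave unreadable from compound 1 to compound 3 cannot be sized because of the limit of > 50000 nM in this assay, at which 2 of the 3 values shown sit. Compound 4 `CCn1c(C(=O)OCc2ccc(F)cc2)ccc1C(CC)(CC)c1ccc(OCC(O)C(C)(C)C)c(C)c1` carries the same change relative to compound 3, (4-fluorophenyl in place of pyridin-2-yl on a saturated chain carbon bound to an oxygen next to a carbonyl group), at the same place as in the first pair. Drawing on compound 2, whose value 9500 nM lies inside the measurable range, compound 4 is expected to show an at least 2.5-fold lower number from compound 3 to compound 4 (0.39 log units; beyond the scatter). Compound 4 is estimated at 20000 nM in this assay, between 5000 nM and 50000 nM, with a fair chance that only a limit is returned.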

Compound 4, half-maximal effective concentration: > 50000 nM
Compound 4 was reported as a limit; the forecaster's own chance of this, stated with the estimate: 35%; middle value at least 2.5-fold (0.39 log units) away from the limit.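

In this assay compound 4 gives > 50000 nM, which is a limit and not a number. The step from pyridin-2-yl to 4-fluorophenyl on the core of compound 3 cannot be read, nor can any other step ending on two limits, because the values at both ends rest on the same limit: the limit of > 50000 nM in this assay, at which 3 of the 4 values shown sit. The data thus neither confirm nor rule out that this change carries from one core to the other, while 1-hydroxy-2,2-dimethylpropyl in place of (tert-butyl)carbonyl brought an at least 5.2-fold higher number from compound 2 to compound 4 (0.72 log units; beyond the scatter).

Left open is how an amine or a carboxylic acid in place of the 1-hydroxy-2,2-dimethylpropyl group would read. Also open, going by these compounds, is whether any ester on the core of compound 3 would give a value inside the measurable range.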